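Nitro to Chloro on the Outer Aryl Ring

The source may hold more compounds than are shown below. What is called first, only, known or untested is meant among the compounds shown, and "the series" means these compounds.

Compound 1 `CS(=O)(=O)Nc1ccc([N+](=O)[O-])cc1OCc1ccc([N+](=O)[O-])cc1` gives 400 nM in an assay on SK-BR-3 cells for inhibition of Aromatase (Homo sapiens); on this read-out higher numbers stand for weaker inhibition and lower numbers for stronger inhibition. Compound 2 `CS(=O)(=O)Nc1ccc([N+](=O)[O-])cc1OCc1ccc(Cl)cc1` gives 290 nM in this assay. The change between them is chloro in place of nitro on an aromatic carbon, and it produces a 1.4-fold lower number from compound 1 to compound 2 (0.14 log units; within the scatter). Compound 3 `O=C(Nc1ccc([N+](=O)[O-])cc1OCc1ccccc1)c1ccc(Cl)c([N+](=O)[O-])c1` reaches only the limit of the assay, > 25000 nM, in this assay. The difference between the two cores is not broken down here. Compound 4 `O=C(Nc1ccc([N+](=O)[O-])cc1OCc1ccccc1)c1ccc(Cl)c(Cl)c1` is still to be measured in this assay; it differs from compound 3 by chloro in place of nitro on an aromatic carbon. This is the same kind of change as from compound 1 to compound 2, though the place differs: in compound 4 the chloro sits ortho to a chloro group and meta to a large group, whereas in compound 2 it sits para to a large group. The expectation for compound 4 rests on a 1.4-fold lower number from compound 1 to compound 2 (0.14 log units; within the scatter) and on (the limit of > 25000 nM in this assay, at which 1 of the 3 values shown sits). From compound 3 to compound 4 the expected step is a number no higher from compound 3 to compound 4 (the limit leaves the size open). Compound 4 is estimated at 25000 nM, within 8000 nM to 100000 nM.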

Compound 4, half-maximal inhibitory concentration: > 25000 nM
Compound 4 was reported as a limit (the forecaster's own chance of this, stated with the estimate: 75%); the middle value sits exactly at the limit.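

For the compounds shown here, compound 3 and compound 4 both stand at a limit of the assay and not at a number, so no step between them can be read: the limit of > 25000 nM in this assay, at which 2 of the 4 values shown sit. As far as these compounds go, how far either compound lies past that limit, and whether chloro in place of nitro changes anything on the core of compound 3, stays open.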